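Cytotoxicity notes on an oxazole piperidine carboxamide series

The compounds below may be only part of what the source reports. "The series", "measured", "known", "first", "only" and "open" are said of these compounds alone.

Measured compounds:
compound 1 `Cc1oc(-c2c(Cl)cccc2Cl)nc1CN1CCC(C(=O)NCCCN2C[C@H](C)C[C@H](C)C2)CC1` — 13200 nM
compound 2 `Cc1ccccc1-c1nc(CN2CCC(C(=O)NCCCCN3C[C@H](C)C[C@H](C)C3)CC2)c(C)o1` — 23100 nM
compound 3 `Cc1ccccc1-c1nc(CN2CCC(C(=O)N3CCN(C4CCN(C)CC4)CC3)CC2)c(C)o1` — 19900 nM

All three numbers come from an ADME assay on Huh7.5.1 cells (Homo sapiens) for cytotoxicity, read by ATP content, with a stated time of 48 h; a higher number here means that more compound is tolerated, a lower number that less compound is tolerated. Compound 1 gives the smallest of the three figures, but its gap to compound 3 and its gap to compound 2 both lie within the scatter of repeated measurements, so the three compounds cannot be told apart on tolerance in this assay. Among the measured compounds shown here, no pair among them differs in a single place, so no single step is counted.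

The unmeasured compound is compound 4 `COc1cccc(C)c1-c1nc(CN2CCC(C(=O)NCCCN3C[C@H](C)C[C@H](C)C3)CC2)c(C)o1`. Against compound 1 the change is 2-methoxy-6-methylphenyl in place of 2,6-dichlorophenyl on an aromatic carbon. The rest of the shared core, the piperidine carboxamide and the dimethylpiperidine chain, is unchanged.

For the measured compounds named here, no measured step exceeds the scatter, and the three compounds, which differ from one another in several places, all give numbers within a narrow band. An exchange of one aryl group for another on the same aromatic carbon is therefore expected to leave the number within the scatter; the estimated step is a 1.2-fold higher number from compound 1 to compound 4 (0.08 log units; within the scatter), in no firm direction. Compound 4 is expected to give about 16000 nM in this assay, with a range from 7000 nM to 35000 nM.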

Compound 4, half-maximal cytotoxic concentration: 16700 nM
Compound 4: the middle estimate sits 1.0-fold (0.02 log units) below what was measured; the measured number falls inside the stated range.
By their numbers in this assay, from the lowest: compounds 1, 4, 3 and 2 (each within the scatter of the next).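

With 2-methoxy-6-methylphenyl in place of 2,6-dichlorophenyl on an aromatic carbon of a five-membered aromatic ring with 1 nitrogen and 1 oxygen, this assay gives a 1.3-fold higher number from compound 1 to compound 4 (0.10 log units; within the scatter), and this is the only step shown that changes a single place. Among the compounds shown here, at this position, then, an aryl group carrying chlorine and no hydrogen-bond acceptor and one carrying oxygen and a hydrogen-bond acceptor cannot be told apart on tolerance, which the earlier compounds, differing in several places at once, could not show. No supporting data bear on this result.

On these data alone, whether an unsubstituted phenyl, a cyclohexyl group or a phenyl bearing a carboxylic acid or an amine on this same aromatic carbon would move the number beyond the scatter stays open. On the amide side the compounds shown offer no pair differing in one place, so what a morpholine or a carboxylic acid would do in place of the dimethylpiperidine also remains open.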